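Methoxy to bromo, read across two cores

A few compounds are considered here, and "the series" means these few. Any claim that something is new, unique, unknown or untested is made for them only; others in the source may bear on it.

Compound 1 `CCOC(=O)c1csc2nc(CN3CCN(C)CC3)c(-c3ccc(OC)cc3)n12` and compound 2 `CCOC(=O)c1csc2nc(CN3CCN(C)CC3)c(-c3ccc(Br)cc3)n12` share one core and differ only in the substituent on the phenyl ring. In a functional assay on PC-3 cells (Homo sapiens) for antiproliferative activity, read by MTT assay, with a stated time of 72 h (on this read-out higher numbers stand for weaker inhibition and lower numbers for stronger inhibition), compound 1 gives 69400 nM, and compound 2 gives 85000 nM. The change between them is bromo in place of methoxy on an aromatic carbon and it made a 1.2-fold higher number from compound 1 to compound 2 (0.09 log units; within the scatter). Compound 3 `COc1ccc(-c2cnc3scc(C(=O)NNC(C)=O)n23)cc1` rests on a second core; the difference between the two cores is not broken down here. In this assay compound 3 gives 28300 nM, the lowest of the three numbers, and its gap to compound 1 as well as to compound 2 lies beyond the scatter. Compound 4 `CC(=O)NNC(=O)c1csc2ncc(-c3ccc(Br)cc3)n12` is not yet measured and differs from compound 3 by bromo in place of methoxy on an aromatic carbon, the same change as between compound 1 and compound 2, at the same place. Because a 1.2-fold higher number from compound 1 to compound 2 (0.09 log units; within the scatter) stayed within the scatter, the step from compound 3 to compound 4 is expected to be a 1.2-fold higher number from compound 3 to compound 4 (0.08 log units; within the scatter), a small one in the same direction. Compound 4 is accordingly estimated at 34000 nM in this assay, with a likely range from 14000 nM to 85000 nM.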

Compound 4, half-maximal inhibitory concentration: 12700 nM
Beside the measured number, compound 4's estimate is 2.7-fold (0.43 log units) above it, and the stated range ends above it.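

In this assay, bromo in place of methoxy on an aromatic carbon gives a 2.2-fold lower number from compound 3 to compound 4 (0.35 log units; beyond the scatter), so on the core of compound 3 the change registers as a modest gain in inhibition. The step does not carry over in size from the core of compound 1, and the two cores cannot be treated as interchangeable for this change: the same change on two cores in this assay, a 1.2-fold higher number (0.09 log units; within the scatter) from compound 1 to compound 2 and a 2.2-fold lower number (0.35 log units; beyond the scatter) from compound 3 to compound 4, 2.7-fold (0.44 log units) apart, beyond the scatter of two such steps. With a single pair on each core, this shows that the outcome of the change differs between these two cores, but it does not show which part of the cores accounts for the difference, nor does it give a rule for any further core.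

Still open, on these data alone, is whether another group at the same place, such as chloro, methyl or an amine, would follow the step seen on the core of compound 1 or the one seen on the core of compound 3. Also open, as far as these compounds go, is whether the difference between the two steps holds in any read-out outside this assay.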